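Trimming the hydroxypropoxy tail of compound 3 to methoxy

A few compounds are considered here, and "the series" means these few. Any claim that something is new, unique, unknown or untested is made for them only; others in the source may bear on it.

Three cinnamide-indole compounds have been measured in an assay on C6 cells for antagonist activity at prostaglandin E2 receptor EP2 subtype (Homo sapiens), read by TR-FRET, with stated times of 10 min and 40 min, tested at 1 uM; a lower number here means a stronger inhibitor, a higher number a weaker inhibitor. Compound 1 `O=C(/C=C/c1ccc(OCCO)c(OCCO)c1)NCCn1c(C(F)(F)F)cc2ccccc21` gives 260 nM, compound 2 `COc1cc(/C=C/C(=O)NCCn2c(C(F)(F)F)cc3ccccc32)cc(OC)c1OCCO` gives 58.3 nM, and compound 3 `Cc1cc2ccccc2n1CCNC(=O)/C=C/c1ccc(OCCCO)cc1` gives 11.8 nM. Compound 3 therefore has the lowest number of the three, and it is the strongest inhibitor here, since its gap to compound 2 and its larger gap to compound 1 both lie beyond the usual scatter.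

Compound 4 `COc1ccc(/C=C/C(=O)NCCn2c(C)cc3ccccc32)cc1` differs from compound 3 by one change: hydrogen in place of 2-hydroxyethyl on a saturated chain carbon bound to an oxygen on an aromatic ring. Going by the values given here, no measured pair shows this change on its own, so its effect is uncertain; a modest weakening is expected, with a 1.9-fold higher number from compound 3 to compound 4 (0.27 log units; within the scatter) in this assay. Compound 4 is estimated at 22 nM, within a range from 6 nM to 80 nM.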

Compound 4, antagonist equilibrium constant: 16.5 nM
The estimate for compound 4 lay 1.3-fold (0.12 log units) above the measured number; the range from low to high includes it.
By their numbers in this assay, from the lowest: compounds 3 and 4 (each within the scatter of the next); then compound 2; then compound 1.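

The step of a 1.4-fold higher number from compound 3 to compound 4 (0.15 log units; within the scatter) means that the 3-hydroxypropoxy and methoxy compounds cannot be told apart in this read-out. At this place, the 2-hydroxyethyl portion, with its hydrogen-bond donor, can therefore be removed without a difference beyond the scatter, so the terminal hydroxyl is not needed to hold this number. No supporting data are available to explain this result.

Still open, on these data alone, is whether an amine or a carboxylic acid at the end of this chain would give a different number. Also open, as far as these compounds go, is how a longer chain would behave here.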